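Turning One Ring Stereocentre in Compound 1

A few compounds are considered here, and "the series" means these few. Any claim that something is new, unique, unknown or untested is made for them only; others in the source may bear on it.

Compound 1 `CC1=C(c2cccc(O)c2)[C@H](c2ccc(OC[C@H](C)N3CC[C@@H](C)C3)cc2)Oc2ccc(O)cc21`: 0.1 nM
Compound 2 `CC1=C(c2cccc(O)c2)C(c2ccc(OC[C@H](C)N3CCCC3)cc2)Oc2ccc(O)cc21`: 0.2 nM
Compound 3 `CC1=C(c2cccc(O)c2)[C@@H](c2ccc(OC[C@H](C)N3CC[C@@H](C)C3)cc2)Oc2ccc(O)cc21`: not yet measured

In a functional assay on MCF7 cells (Homo sapiens) for antiproliferative activity, read by CellTiter-Glo, with a stated time of 5 days (on this read-out lower numbers stand for stronger inhibition and higher numbers for weaker inhibition), compound 1 (0.1 nM) and compound 2 (0.2 nM) lie within the scatter of each other. Compound 3 has the same atoms and bonds as compound 1 and differs only in configuration as drawn (the two compounds have the same atoms and bonds and differ only in configuration as drawn: 1 of 3 stereo elements differ; a stereocentre at a saturated ring carbon is drawn S in compound 1 and R in compound 3): a stereocentre at a saturated ring carbon is drawn S in compound 1 and R in compound 3. Within the data shown here, no measured pair isolates this carbon, so the estimate stays wide. Compound 1 already gives a very low number (0.1 nM), which leaves little room downward. The expected change in this assay is a rise beyond the scatter, a 30-fold higher number from compound 1 to compound 3 (1.48 log units; beyond the scatter), toward weaker inhibition. Compound 3 is estimated at 3 nM (expected range 0.3 nM to 30 nM).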

Compound 3, half-maximal inhibitory concentration: 59 nM
Estimate against measurement, compound 3: 20-fold (1.29 log units) below; measured number above the stated range.
By their numbers in this assay, from the lowest: compounds 1 and 2 (each within the scatter of the next); then compound 3.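

In this assay, turning the saturated ring carbon from S to R gives a 590-fold higher number from compound 1 to compound 3 (2.77 log units; beyond the scatter). Among these compounds, this carbon, which the earlier compounds did not isolate, is therefore highly sensitive to configuration, and the S form is clearly preferred in this pair. The gap can be assigned to this one carbon alone because nothing else changes: the fact that compounds 1 and 3 differ only in the configuration as drawn.

As far as these compounds go, compound 2 is drawn without a configuration at this carbon, so the size of the gap without the methyl on the amine ring remains open. Also open, from the compounds shown here alone, is whether a carboxylic acid in place of that amine would show the same preference.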